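The compounds below may be only part of what the source reports. "The series", "measured", "known", "first", "only" and "open" are said of these compounds alone.

Values in an ADME assay on Huh-7 cells (Homo sapiens) for cytotoxicity, with a stated time of 72 h; a higher number here means that more compound is tolerated, a lower number that less compound is tolerated:
- Compound 1 `CC(C)CCn1nc(-c2cccs2)c(O)c(C2=NS(=O)(=O)c3cc(S(C)(=O)=O)ccc3N2)c1=O`: "not determined" (no result reported)
- Compound 2 `CS(=O)(=O)Nc1ccc2c(c1)S(=O)(=O)N=C(c1c(O)c(-c3ccc(Cl)s3)nn(CCC3CC3)c1=O)N2`: > 33000 nM
- Compound 3 `CC(C)CCn1nc(-c2ccccc2)c(O)c(C2=NS(=O)(=O)c3cc(NS(C)(=O)=O)ccc3N2)c1=O`: > 1000 nM

In this assay compound 3 stands at > 1000 nM, which is a limit and not a number. Compound 4 `CC(C)CCn1nc(CC2CCC2)c(O)c(C2=NS(=O)(=O)c3cc(NS(C)(=O)=O)ccc3N2)c1=O` has cyclobutylmethyl in place of phenyl on an aromatic carbon. For the measured compounds named here, the series offers no measured step for this change. The expectation rests on compound 2, whose > 33000 nM is also a limit. The expected step that the limit leaves unreadable from compound 3 to compound 4 points towards more compound tolerated in this assay, and it is only an estimate. For compound 4 the estimated value is 20000 nM, with an expected range of 5000 nM to 60000 nM.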

Compound 4, half-maximal cytotoxic concentration: > 33000 nM
Compound 4: a limit, no number (the forecaster's own chance of this, stated with the estimate: 80%); middle value at least 1.6-fold (0.21 log units) away from the limit.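

For the compounds shown here, compound 3 and compound 4 both carry limits rather than numbers, so no step between them can be read. The compounds shown leave open what cyclobutylmethyl in place of phenyl changes in this assay.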